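Chloro in Place of Methyl: From Compound 3 to Compound 4

The source may hold more compounds than are shown below. What is called first, only, known or untested is meant among the compounds shown, and "the series" means these compounds.

In a functional assay on MNK45 cells (Homo sapiens) for inhibition, read by MTT assay, with a stated time of 48 h (on this read-out higher numbers stand for weaker inhibition and lower numbers for stronger inhibition), compound 3 `Cc1ccc(NC(=S)NC(=O)c2ccc(OCc3ccc(Cl)c(Cl)c3)cc2)cc1-c1nc2ccccc2[nH]1` gives 8410 nM. Compound 1 `Cc1ccc(COc2ccc(C(=O)NC(=S)Nc3ccc(C)c(-c4nc5ccccc5[nH]4)c3)cc2)cc1` gives 11300 nM in this assay, and compound 2 `Cc1ccc(NC(=S)NC(=O)c2ccc(OCc3ccccc3Cl)cc2)cc1-c1nc2ccccc2[nH]1` gives 51400 nM. Compound 3 has the smallest number of the three, but a 1.3-fold lower number from compound 1 to compound 3 (0.13 log units; within the scatter) stays within the scatter, while a 6.1-fold lower number from compound 2 to compound 3 (0.79 log units; beyond the scatter) and a 4.5-fold higher number from compound 1 to compound 2 (0.66 log units; beyond the scatter) are larger. All three measured steps concern the group on the saturated chain carbon bound to an oxygen, not the ring carrying the benzimidazolyl group. Compound 4 `O=C(NC(=S)Nc1ccc(Cl)c(-c2nc3ccccc3[nH]2)c1)c1ccc(OCc2ccc(Cl)c(Cl)c2)cc1` differs from compound 3 by chloro in place of methyl on an aromatic carbon. Among the measured compounds shown here, no measured step touches this position, so the expectation rests on compound 3 alone and is for no step beyond the scatter, a 1.1-fold lower number from compound 3 to compound 4 (0.02 log units; within the scatter). Compound 4 is therefore estimated at 8000 nM, between 3000 nM and 25000 nM.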

Compound 4, half-maximal inhibitory concentration: 4600 nM
Compound 4: the middle estimate sits 1.7-fold (0.24 log units) above what was measured; the range from low to high includes it.
By their numbers in this assay, from the lowest: compounds 4, 3 and 1 (each within the scatter of the next, the first and the last beyond it); then compound 2.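

In this assay the aromatic carbon ortho to a 1H-benzimidazol-2-yl group now has its first measured step, and chloro in place of methyl there stays within the scatter (a 1.8-fold lower number from compound 3 to compound 4 (0.26 log units; within the scatter)). So far, this change at this position counts for less than the exchange of the aryl group that separates compound 2 from compound 1 and compound 3. Nothing available explains this result. As far as these compounds go, whether an amine or a methoxy group at this position would also stay within the scatter remains open. So does whether chloro in place of methyl behaves alike with the 2-chlorophenyl group of compound 2.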